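The compounds below may be only part of what the source reports. "The series", "measured", "known", "first", "only" and "open" are said of these compounds alone.

In a functional assay on the whole organism (strain Sprague-Dawley) for inhibition, with Rattus norvegicus as the target, with a stated time of 10 min (a higher number here means that more compound is needed for the effect, a lower number that less compound is needed), compound 1 `O=C(O)c1cnc(-c2ccccc2F)[nH]c1=O` gives 5 mg/kg, while compound 2 `Nc1ccccc1-c1ncc(C(=O)O)c(=O)[nH]1` gives 50 mg/kg. Compound 2 therefore holds the higher of the two numbers, and more of it is needed for the effect. The next compound, compound 3 `CCCOc1ccccc1-c1ncc(C(=O)O)c(=O)[nH]1`, has not yet been measured. It keeps the core of compound 2 but carries propoxy in place of amino on an aromatic carbon, ortho to a large group: propoxy in place of amino on an aromatic carbon.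

Within the data shown here, only one measured step bears on this change: a 10-fold higher number from compound 1 to compound 2 (1.00 log units; beyond the scatter). This modest step, beyond the scatter, involves amino entering at the same place that amino now leaves. Among the measured compounds shown here, no measured compound carries propoxy, so the data give only an indirect guide, and the size of the change remains uncertain. Removing amino is expected to bring the number down by a similar amount, an expected change of a 10-fold lower number from compound 2 to compound 3 (1.00 log units; beyond the scatter). For compound 3 the estimated dose is 5 mg/kg, with an expected range from 1 mg/kg to 25 mg/kg.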

Compound 3, dose for 50% inhibition: 0.9 mg/kg
Beside the measured number, compound 3's estimate is 5.6-fold (0.74 log units) above it, and the stated range ends above it.
By their numbers in this assay, from the lowest: compound 3; then compound 1; then compound 2.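

In this assay, the position on the aromatic carbon ortho to a large group proves able to take a far larger group than fluoro or amino, and propoxy gives a 56-fold lower number from compound 2 to compound 3 (1.74 log units; beyond the scatter). Propoxy also improves on fluoro, the better of the two earlier groups, with a 5.6-fold lower number from compound 1 to compound 3 (0.74 log units; beyond the scatter), so compound 3 needs the least compound of the three and the position spans a wider range than the single earlier step had revealed. No measurement in hand accounts for these differences.

The compounds shown leave open whether the gain depends on the chain, on the ether oxygen, or on both, since a methoxy or ethoxy group, a butoxy chain, or a plain propyl group attached directly to the ring would be needed to separate these. They also leave open whether propoxy would have the same effect at other places on this aromatic ring, or with the carboxylic acid on the core replaced by an amide or an ester.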